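Shifting the thiophene attachment point in an imidazoline agonist series

This account rests on a few compounds, and the source may have more. Where it says the series, first, only, none or still open, it means among the compounds named here.

Measured so far:
- compound 1, `c1coc(-c2ccccc2OCC2=NCCN2)c1`, in a functional assay for activation of Alpha-1A adrenergic receptor (Homo sapiens), read by calcium flux (on this read-out lower numbers stand for an effect already at smaller amounts and higher numbers for an effect only at larger amounts of compound), compound 1 gives 1.26 nM
- compound 2, `c1csc(-c2ccccc2OCC2=NCCN2)c1`, in this assay compound 2 gives 1 nM

Compound 2 has the lowest of the two numbers in this assay, but its neighbour compound 1 lies within the scatter, so the two cannot be ordered. Going by the values given here, the only measured step, a 1.3-fold lower number from compound 1 to compound 2 (0.10 log units; within the scatter), swaps one five-membered heteroaromatic ring for another at the same attachment point and changes nothing beyond the scatter.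

Compound 3, `c1ccc(-c2ccsc2)c(OCC2=NCCN2)c1`, differs from compound 2 in thiophen-3-yl in place of thiophen-2-yl on an aromatic carbon. Among the compounds with values here, no measured step here changes where the five-membered ring is joined, so the furan-to-thiophene step only suggests that this part of the molecule tolerates modest variation. For compound 3 in this assay a small step is therefore expected, a 2.0-fold higher number from compound 2 to compound 3 (0.30 log units; within the scatter), with the expected value being 2 nM within a range from 0.5 nM to 8 nM.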

Compound 3, half-maximal effective concentration: 0.251 nM
Compound 3: middle estimate off by 8.0-fold (0.90 log units), on the high side; the whole stated range lies above it.
By their numbers in this assay, from the lowest: compound 3; then compounds 2 and 1 (each within the scatter of the next).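

The same atoms, joined differently, have a clearer effect at this position than the earlier ring swap: replacing thiophen-2-yl with thiophen-3-yl in this assay gives a 4.0-fold lower number from compound 2 to compound 3 (0.60 log units; beyond the scatter), while furan-2-yl and thiophen-2-yl could not be told apart. Replacing furan-2-yl with thiophen-3-yl gives a similar result, a 5.0-fold lower number from compound 1 to compound 3 (0.70 log units; beyond the scatter), so in this small set the way the five-membered ring is joined to the six-membered aromatic ring can shift the number beyond the scatter. No available measurement explains this difference.

From the compounds shown here alone, the furan appears here only as furan-2-yl, so it remains open whether furan-3-yl would show the same shift. Also open, going by these compounds, is how a six-membered ring, such as phenyl or pyridin-3-yl, would behave at this place.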